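Isopropyl for methyl at the chain carbon of compound 2

The source may hold more compounds than are shown below. What is called first, only, known or untested is meant among the compounds shown, and "the series" means these compounds.

Measured compounds:
compound 1 `CC(C)C[C@@H](c1nc2ccc(C(=O)O)cc2n1C)N1C(=O)CN(c2cccc(Oc3ccccc3)c2)C1=O` — 18200 nM
compound 2 `C[C@@H](c1nc2ccc(C(=O)O)cc2n1C)N1C(=O)CN(c2ccc(Oc3ccccc3)cc2)C1=O` — 10400 nM
compound 3 `CC(C)C[C@@H](c1nc2ccc(C(=O)O)cc2n1C)N1C(=O)CN(c2ccc(-c3ccccc3)cc2)C1=O` — 23100 nM

In an assay on isolated protein for inhibition of Bile acid receptor (Homo sapiens), read by TR-FRET and LanthaScreen (a lower number here means a stronger inhibitor, a higher number a weaker inhibitor), compound 2 gives 10400 nM, the lowest of the three numbers. Compound 1 gives 18200 nM in this assay, which lies within the scatter of compound 2; compound 3 gives 23100 nM, a gap to compound 2 that is beyond the scatter. Among the compounds with values here, compounds 1 and 3 both differ from compound 2 in more than one place, so no single-change step between measured compounds is available, and nothing is known here about how the compounds bind.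

Compound 4 `CC(C)[C@@H](c1nc2ccc(C(=O)O)cc2n1C)N1C(=O)CN(c2ccc(Oc3ccccc3)cc2)C1=O` is not yet measured. It is compound 2 with isopropyl in place of methyl on a saturated chain carbon bound to an amide-type nitrogen in a ring and an aromatic carbon. The measured set gives no direct reading of this change; all three numbers sit in a narrow band, and the substituent on that carbon has not been varied on its own. The expected step from compound 2 to compound 4 is therefore small, a 1.3-fold higher number from compound 2 to compound 4 (0.10 log units; within the scatter), most likely none beyond the scatter, with a slight lean toward a higher number. Compound 4 is expected to give about 13000 nM in this assay, in a range from 6000 nM to 30000 nM.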

Compound 4, half-maximal inhibitory concentration: 175000 nM
Beside the measured number, compound 4's estimate is 13-fold (1.13 log units) below it, outside the stated range (above it).
By their numbers in this assay, from the lowest: compounds 2, 1 and 3 (each within the scatter of the next, the first and the last beyond it); then compound 4.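

In this assay, isopropyl in place of methyl on the saturated chain carbon gives a 17-fold higher number from compound 2 to compound 4 (1.23 log units; beyond the scatter), a large step that lies beyond the scatter. Within the data shown here, this carbon is therefore not indifferent to its substituent, which the earlier compounds could not show: their numbers lie close together, and none of them forms a single-change pair with another. Among these compounds, no supporting data bear on why this change raises the number so far, and the reading holds only with the rest of compound 2 unchanged.

One pair cannot tell whether the number climbs gradually from methyl to isopropyl or jumps at some point along the way; ethyl or cyclopropyl on this carbon would separate those two cases. Among the compounds shown here, also open is whether the same change gives a step of similar size when the aromatic group on the far side of the shared core is different, since no second pair carrying methyl and isopropyl on this carbon is available.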